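The source may hold more compounds than are shown below. What is called first, only, known or untested is meant among the compounds shown, and "the series" means these compounds.

Measured compounds: compound 1 `Cn1cccc1-c1ncnc2c1ncn2C1O[C@H](CO)[C@@H](O)[C@H]1O`, compound 2 `OC[C@H]1OC(n2cnc3c(-c4nccs4)ncnc32)[C@H](O)[C@@H]1O`.

In a functional assay on HL-60 cells (Homo sapiens) for inhibition (on this read-out lower numbers stand for stronger inhibition and higher numbers for weaker inhibition), compound 1 gives 15700 nM. In this assay compound 2 gives 6300 nM. Going by the values given here, compound 2 stands at the lower of the two numbers; the single step within the pair, a 2.5-fold lower number from compound 1 to compound 2 (0.40 log units; beyond the scatter), is modest and beyond the scatter.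

Compound 3 `OC[C@H]1OC(n2cnc3c(-c4cc[nH]c4)ncnc32)[C@H](O)[C@@H]1O` is not yet measured. Its change from compound 2 is 1H-pyrrol-3-yl in place of 1,3-thiazol-2-yl on an aromatic carbon. Among the compounds with values here, the only step that bears on this is a 2.5-fold lower number from compound 1 to compound 2 (0.40 log units; beyond the scatter), which replaced a pyrrole by the thiazole; compound 3 reverses that in part, returning to a pyrrole, though as 1H-pyrrol-3-yl rather than 1-methyl-1H-pyrrol-2-yl. Nothing measured separates those two pyrroles, so the expectation rests on that one step alone. A step toward a higher number is expected, of roughly the same modest size as that one, or smaller. For compound 3 the estimate is 11000 nM (range 4500 nM to 27000 nM), which means an expected step of a 1.7-fold higher number from compound 2 to compound 3 (0.24 log units; within the scatter).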

Compound 3, half-maximal inhibitory concentration: 3200 nM
Beside the measured number, compound 3's estimate is 3.4-fold (0.54 log units) above it; the measured number lies below the stated range.
By their numbers in this assay, from the lowest: compounds 3 and 2 (each within the scatter of the next); then compound 1.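

In this assay, 1H-pyrrol-3-yl in place of 1,3-thiazol-2-yl gives a 2.0-fold lower number from compound 2 to compound 3 (0.29 log units; within the scatter), so the two groups cannot be told apart at this position on the shared core. The identity of the pyrrole does matter here: 1H-pyrrol-3-yl in place of 1-methyl-1H-pyrrol-2-yl gives a 4.9-fold lower number from compound 1 to compound 3 (0.69 log units; beyond the scatter), which separates two pyrroles that earlier had to be treated alike. Nothing available gives a reason for this gap between the two pyrroles.

The change from compound 1 to compound 3 alters both the nitrogen methyl and the point of attachment, and the compounds shown do not divide the step between the two; 1H-pyrrol-2-yl would address this. Also open, as far as these compounds go, is how a six-membered ring such as phenyl, or an amine, would compare at this position.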